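Lengthening the Chain of Compound 1 with Hexyl

The source may hold more compounds than are shown below. What is called first, only, known or untested is meant among the compounds shown, and "the series" means these compounds.

- compound 1 `CCCCS(=O)(=O)c1ccc(O)c(C(=O)Nc2ccc(C(F)(F)F)cc2)c1`: 3.1
- compound 2 `CCCCCCCCS(=O)(=O)c1ccc(O)c(C(=O)Nc2ccc(C(F)(F)F)cc2)c1`: 5.26
- compound 3 `CCCCCCS(=O)(=O)c1ccc(O)c(C(=O)Nc2ccc(C(F)(F)F)cc2)c1`: 4.18

In a physicochemical assay for lipophilicity (on this read-out higher numbers stand for higher lipophilicity and lower numbers for lower lipophilicity), compound 1 stands lowest of the three measured compounds, at 3.1. The compound still to be measured is compound 4 `CCCCCCCCCCS(=O)(=O)c1ccc(O)c(C(=O)Nc2ccc(C(F)(F)F)cc2)c1`. It differs from compound 1 by hexyl in place of hydrogen on a saturated chain carbon, four bonds along the chain from a sulfonyl sulfur.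

Going by the values given here, three measured steps bear on this change, all on the same chain. Ethyl in the same place gave a number 1.08 log units higher from compound 1 to compound 3 (beyond the scatter). Butyl there gave a number 2.16 log units higher from compound 1 to compound 2 (beyond the scatter). Going back from the longer chain, hydrogen in place of ethyl gave a number 1.08 log units lower from compound 2 to compound 3 (beyond the scatter). Among these three compounds the number rises with each longer chain, and none goes against that. The hexyl change goes further along the same line, so a large upward step is expected, greater than a number 2.16 log units higher from compound 1 to compound 2 (beyond the scatter). As far as these compounds go, no chain longer than that of compound 2 has yet been measured, so the continuation of this trend remains untested. The expected step is a number 3.20 log units higher from compound 1 to compound 4 (beyond the scatter). For compound 4 the estimated value is 6.3, with an expected range of 5.7 to 6.7.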

Compound 4, distribution coefficient: 6.34
For compound 4 the middle estimate is 0.04 log units below the measured one; the range from low to high includes it.
By their numbers in this assay, from the lowest: compound 1; then compound 3; then compound 2; then compound 4.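

In this assay the rise does not stop at the chain of compound 2: the ethyl change on that longer chain gives a number 1.08 log units higher from compound 2 to compound 4 (beyond the scatter) and so matches in size a number 1.08 log units higher from compound 1 to compound 3 (beyond the scatter) at the shorter end of the series. The butyl change likewise gives a number 2.16 log units higher from compound 3 to compound 4 (beyond the scatter) and matches a number 2.16 log units higher from compound 1 to compound 2 (beyond the scatter), while the full hexyl change gives a number 3.24 log units higher from compound 1 to compound 4 (beyond the scatter) and so extends the series, in which each lengthening by the same number of chain carbons adds the same amount across all four compounds and none goes against the pattern. Nothing available explains why the steps are so even.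

As far as these compounds go, all four compounds carry unbranched saturated chains on the sulfonyl sulfur, so it remains open whether a longer chain than that of compound 4 would continue the same even rise or whether the number would level off. Also open, from the compounds shown here alone, is how a branched chain, an ether oxygen within the chain, or a carboxylic acid or an amine at the chain end would change the number in this assay on the shared core.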